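Hydroxy to (ethylsulfanyl)methyl on the side chain

This account rests on a few compounds, and the source may have more. Where it says the series, first, only, none or still open, it means among the compounds named here.

Measured so far:
compound 1 `CN1CCN(c2nc3ccccc3n2CCO)CC1` — 410 nM
compound 2 `CCOCCn1c(N2CCN(CC)CC2)nc2ccccc21` — 18 nM
compound 3 `CCCCOCCn1c(N2CCCN(C)CC2)nc2ccccc21` — 10 nM

Three compounds share the core of compound 1 and differ in the chain on the aromatic nitrogen and in the saturated ring attached to the core. In a functional assay on ileum for inhibition of histamine H1 receptor (Cavia porcellus) (on this read-out higher numbers stand for weaker inhibition and lower numbers for stronger inhibition), compound 1 gives 410 nM, the highest number of the three; compound 2 gives 18 nM and compound 3 gives 10 nM, both far below compound 1 and both beyond the scatter. No pair of these compounds differs in one place only, so no single step is defined among them; what can be said is that the one compound carrying a hydroxy, compound 1, stands well above the other two.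

Compound 4 `CCSCCCn1c(N2CCN(C)CC2)nc2ccccc21` has not been measured in this assay. Against compound 1 the change is (ethylsulfanyl)methyl in place of hydroxy on a saturated chain carbon, two bonds along the chain from an aromatic nitrogen. Compound 4 keeps the ring and core of compound 1, so the step from compound 1 to compound 4 isolates the chain. Given that compound 2, which carries no hydroxy, gives 18 nM and compound 3, also without a hydroxy, gives 10 nM, both far below compound 1, the step of a 16-fold lower number from compound 1 to compound 4 (1.21 log units; beyond the scatter) is expected to be a large fall, well beyond the scatter. Compound 4 is estimated at 25 nM, between 7 nM and 90 nM.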

Compound 4, half-maximal inhibitory concentration: 530 nM
Compound 4: the middle estimate sits 21-fold (1.33 log units) below what was measured; measured number outside the range, above it.
By their numbers in this assay, from the lowest: compounds 3 and 2 (each within the scatter of the next); then compounds 1 and 4 (each within the scatter of the next).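

In this assay, among the compounds shown here, hydroxy to (ethylsulfanyl)methyl gives a 1.3-fold higher number from compound 1 to compound 4 (0.11 log units; within the scatter), the first step that changes one place only. On a saturated chain carbon, two bonds along the chain from an aromatic nitrogen, the exchange of hydroxy for this larger group without a hydrogen-bond donor therefore leaves the number within the scatter. The absence of the hydroxy is thus not enough on its own to separate a compound from compound 1, and the low numbers of compound 2 and compound 3, which each differ from compound 4 in more than one place, cannot be assigned to any single feature. No evidence is available that bears on this result.

Still open, as far as these compounds go, is whether the chain, the saturated ring or both set the low numbers of compound 2 and compound 3. An ethoxymethyl group at the same place on the core and ring of compound 1 would test oxygen against sulfur in the chain in a single step, and an amine such as dimethylamino or a longer chain would show how far this position tolerates other groups.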